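The source may hold more compounds than are shown below. What is called first, only, known or untested is meant among the compounds shown, and "the series" means these compounds.

Measured so far:
compound 1 `COc1ccc(C2=NN(C(=O)C3COc4ccccc4O3)C(c3ccc(OC)cc3)C2)cc1` — 11000 nM
compound 2 `COc1ccc(C2CC(c3ccc(Br)cc3)=NN2C(=O)c2ccc3c(c2)OCCO3)cc1` — 5680 nM

In a functional assay on WM 266-4 cells (Homo sapiens) for inhibition, read by MTT assay, with a stated time of 24 h (a lower number here means a stronger inhibitor of growth, a higher number a weaker inhibitor of growth), compound 2 gives 5680 nM, the lowest of the two numbers, though compound 1 with 11000 nM lies within the scatter of it, so no order between them is claimed. Compound 3 `COc1ccc(C2=NN(C(=O)c3ccc4c(c3)OCCO4)C(c3ccc(OC)cc3)C2)cc1` differs from compound 2 by methoxy in place of bromo on an aromatic carbon. Among the measured compounds shown here, no measured pair shows this change, so no step beyond the scatter is expected in either direction. Compound 3 is expected at 8000 nM, within 3000 nM to 25000 nM. The expected step is a 1.4-fold higher number from compound 2 to compound 3 (0.15 log units; within the scatter), small against the scatter.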

Compound 3, concentration for 50% growth inhibition: 9890 nM
Estimate against measurement, compound 3: 1.2-fold (0.09 log units) below; the measured number falls inside the stated range.
By their numbers in this assay, from the lowest: compounds 2, 3 and 1 (each within the scatter of the next).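

In this assay, methoxy in place of bromo on an aromatic carbon gives a 1.7-fold higher number from compound 2 to compound 3 (0.24 log units; within the scatter) and so shows no readable difference between these two groups at this position. On the carbonyl carbon, 2,3-dihydro-1,4-benzodioxin-6-yl in place of 2,3-dihydro-1,4-benzodioxin-2-yl gives a 1.1-fold lower number from compound 1 to compound 3 (0.05 log units; within the scatter) and likewise separates nothing. Nothing at hand bears on these results. On these data alone, whether an amine or a carboxylic acid on this aromatic carbon would give a step beyond the scatter stays open. So does the effect of a longer chain on the carbonyl carbon.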